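Compound 3 from compound 1: a step without an anchor

This account rests on a few compounds, and the source may have more. Where it says the series, first, only, none or still open, it means among the compounds named here.

compound 1 `O=C1CN(S(=O)(=O)c2cc3ccc(Cl)cc3s2)CCN1Cc1cc2[nH]cccc-2n1` — > 2900 nM
compound 2 `O=C1CN(S(=O)(=O)c2cc3ccc(Cl)cc3s2)CCN1Cc1nc2cc[nH]cc-2n1` — > 2900 nM

In an assay on isolated protein for binding affinity to serine protease 1 (Homo sapiens) (a lower number here means a stronger inhibitor, a higher number a weaker inhibitor), compound 1 gives > 2900 nM, a limit of the assay and not a number. Compound 2 in this assay gives > 2900 nM, likewise a limit. The step that the two limits leave unreadable from compound 1 to compound 2 cannot be sized because both values sit at the limit (the limit of > 2900 nM in this assay, at which 2 of the 2 values shown sit). Compound 1 therefore stands nowhere definite on the numbers shown; it is known only to be weaker than the limit of this assay allows to measure.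

Compound 3 `Nc1[nH]ccc2nc(CN3CCN(S(=O)(=O)c4cc5ccc(Cl)cc5s4)CC3=O)cc1-2` differs from compound 1 by a group of 10 heavy atoms (7 carbon, 3 nitrogen; one five-membered aromatic ring with 1 hetero atom, one six-membered aromatic ring with 1 hetero atom) in place of a group of 9 heavy atoms (7 carbon, 2 nitrogen; one five-membered aromatic ring with 1 hetero atom, one six-membered aromatic ring with 1 hetero atom), on a saturated chain carbon bound to an amide-type nitrogen in a ring. Within the data shown here, no measured step bears on this change: the single measured step exchanges the bicyclic arm as a whole and is itself unreadable. The size and direction of the step in this assay are therefore open, and no movement beyond the scatter can be predicted. Compound 3 is expected to give 3000 nM in this assay, within 500 nM to 20000 nM. This estimate means the step that the limit leaves unreadable from compound 1 to compound 3 is expected to remain within the scatter, with a considerable chance that only a limit is again reported.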

Compound 3, inhibition constant in the serine protease 1 assay: > 2900 nM
Compound 3 ended at the assay's limit (the forecaster's own chance of this, stated with the estimate: 60%); the middle value is on the limit's open side.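

In the serine protease 1 assay compound 3 gives > 2900 nM, a limit of the assay and not a number. Among these compounds, no step among compound 1, compound 2 and compound 3 can therefore be read: the limit of > 2900 nM in the serine protease 1 assay, at which 3 of the 3 values shown sit. In a physicochemical assay, compound 1 gives 6.9 and compound 3 gives 9.3. In the physicochemical assay there is a number 2.40 log units higher from compound 1 to compound 3 (beyond the scatter), and the compounds shown leave open whether this shift has any bearing on the serine protease 1 assay.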